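This account rests on a few compounds, and the source may have more. Where it says the series, first, only, none or still open, it means among the compounds named here.

For the measured compounds named here, compound 2 `CC(C)CC(=O)Nc1ncc(-c2cccc(Cl)c2)c(-c2ccccc2)n1` is the one compound with a plain number in hand; in an assay on CHO cells for displacement of a labelled ligand from adenosine receptor A1 (Homo sapiens), read by scintillation counting, with a stated time of 1 h, tested at 1 uM (on this read-out higher numbers stand for more inhibition at the one concentration tested (going by the name of the read-out) and lower numbers for less inhibition), compound 2 gives 56%. Compound 1 `COc1ccc(-c2cnc(N)nc2-c2ccccc2)cc1Cl` stands at a limit of this assay rather than a number, > 80%, as recorded in the limit of > 80% in this assay, at which 1 of the 2 values shown sits. Compound 3 `CN(C)CCNc1ncc(-c2cccc(Cl)c2)c(-c2ccccc2)n1` is not yet measured; it carries 2-(dimethylamino)ethyl in place of isobutylcarbonyl on a nitrogen on an aromatic ring. Going by the values given here, no step between measured compounds is available here, so the change is judged from the structures alone. The expected step from compound 2 to compound 3 is a number 6 percentage points lower from compound 2 to compound 3 (within the scatter), and it could fall either way. For compound 3 the estimate in this assay is 50%, with a range of 15% to 85%.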

Compound 3, a percentage reported as inhibition, at one concentration (the size of the read-out at that concentration, not a potency): 52%
The estimate for compound 3 lay 2 percentage points below the measured number, within the range that was stated.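

In this assay the exchange gives a number 4 percentage points lower from compound 2 to compound 3 (within the scatter) and so does not separate isobutylcarbonyl from 2-(dimethylamino)ethyl on this nitrogen on an aromatic ring. At this place, then, the read-out at the one concentration tested keeps its level without the carbonyl of compound 2. Nothing measured here bears on the cause of this step.

Open, as far as these compounds go, is whether a carboxylic acid, a morpholine or a longer chain at this place would move the number beyond the scatter. Also open, from the compounds shown here alone, is whether any such group reaches the level of the limit held by compound 1.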